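Replacing the diethylamino side chain of compound 3

The source may report more compounds than this note shows. Statements on the series, on what has been measured and on what is new or still open speak of the compounds shown alone.

Compound 1 `COc1cc(OC)c2c(=O)c(OCCCCN3CCCC3)c(-c3cc(OC)c(OC)c(OC)c3)oc2c1`: 10400 nM
Compound 2 `COc1cc(OC)c2c(=O)c(OCCCCN3CCCCC3)c(-c3cc(OC)c(OC)c(OC)c3)oc2c1`: 3030 nM
Compound 3 `CCN(CC)CCCCOc1c(-c2cc(OC)c(OC)c(OC)c2)oc2cc(OC)cc(OC)c2c1=O`: 13000 nM

These values come from a functional assay on MDA-MB-231 cells (Homo sapiens) for cytotoxicity, read by MTT assay, with a stated time of 38 h; a higher number here means a weaker inhibitor, a lower number a stronger inhibitor. Two steps place compound 3 among the others. One stays within the scatter, a 1.3-fold higher number from compound 1 to compound 3 (0.10 log units; within the scatter). The other goes beyond it, a 4.3-fold higher number from compound 2 to compound 3 (0.63 log units; beyond the scatter).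

Compound 4 `COc1cc(OC)c2c(=O)c(OCC(=O)N/N=C/c3ccco3)c(-c3cc(OC)c(OC)c(OC)c3)oc2c1` has not yet been measured, and its change is larger than any seen so far: a group of 10 heavy atoms (6 carbon, 2 nitrogen, 2 oxygen; one five-membered aromatic ring with 1 hetero atom) in place of a group of 8 heavy atoms (7 carbon, 1 nitrogen; no ring), on a saturated chain carbon bound to an oxygen on an aromatic ring. The measured steps only exchange the amino group at the end of the chain. Apart from the step already given, the only other one is a 3.4-fold lower number from compound 1 to compound 2 (0.54 log units; beyond the scatter). Among the measured compounds shown here, those steps are modest at most, and no measured compound carries anything like the entering group, so they offer only a loose guide. No clear step in either direction is expected in this assay, and the uncertainty is wide. The expected change is a 1.3-fold lower number from compound 3 to compound 4 (0.11 log units; within the scatter). For compound 4 the estimate is 10000 nM, with an expected range from 2500 nM to 40000 nM.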

Compound 4, half-maximal inhibitory concentration: 1860 nM
Estimate against measurement, compound 4: 5.4-fold (0.73 log units) above; measured number below the stated range.
By their numbers in this assay, from the lowest: compounds 4 and 2 (each within the scatter of the next); then compounds 1 and 3 (each within the scatter of the next).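

Until now only the amino group at the end of the chain had changed, and compound 4 shows that a very different group, ending in a five-membered aromatic ring, can stand on this saturated chain carbon with cytotoxicity retained in this assay. Against the weaker amines, the exchange gives a 7.0-fold lower number from compound 3 to compound 4 (0.84 log units; beyond the scatter) and a 5.6-fold lower number from compound 1 to compound 4 (0.75 log units; beyond the scatter). Against the piperidin-1-yl chain, it gives a 1.6-fold lower number from compound 2 to compound 4 (0.21 log units; within the scatter), so the new group matches that amine without passing it.

The chain, the nitrogens and the ring all differ at once, and no data here explain the gain or assign it to any one part of the group. As far as these compounds go, whether a phenyl ring in place of the five-membered aromatic ring would hold this level remains open.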